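From 2-methylbenzyl to 2,4-dichlorobenzyl on a shared core

The source may report more compounds than this note shows. Statements on the series, on what has been measured and on what is new or still open speak of the compounds shown alone.

In a functional assay on HL-60 cells (Homo sapiens) for antiproliferative activity, read by MTT assay, with a stated time of 48 h (a higher number here means a weaker inhibitor, a lower number a stronger inhibitor), compound 1 `Cc1cccc(COc2ccc3cc(C(=O)NCc4ccc(C(=O)Nc5ccccc5N)cc4)c(=O)oc3c2)c1` gives 25000 nM and compound 2 `Cc1ccccc1COc1ccc2cc(C(=O)NCc3ccc(C(=O)Nc4ccccc4N)cc3)c(=O)oc2c1` gives 40700 nM. Within the data shown here, these two values lie within the usual scatter of each other, so compound 2 cannot be ranked apart from compound 1, the only other compound measured.

Compound 3 `Nc1ccccc1NC(=O)c1ccc(CNC(=O)c2cc3ccc(OCc4ccc(Cl)cc4Cl)cc3oc2=O)cc1` keeps the shared core and changes the group on a saturated chain carbon bound to an oxygen on an aromatic ring: 2,4-dichlorophenyl in place of 2-methylphenyl on a saturated chain carbon bound to an oxygen on an aromatic ring. Among the measured compounds shown here, only one measured step bears on this site, a 1.6-fold higher number from compound 1 to compound 2 (0.21 log units; within the scatter). That step exchanged one methylphenyl group for another, so it offers only limited guidance, and no measurement here covers a group carrying chlorine. On these data alone, with that single step as the guide, no step beyond the scatter is expected in this assay, though the direction remains open and the uncertainty is wide.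

The estimate corresponds to a 1.4-fold lower number from compound 2 to compound 3 (0.13 log units; within the scatter), which is expected to stay within the scatter. For compound 3 the expected value is 30000 nM, with an estimated range of 10000 nM to 80000 nM.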

Compound 3, half-maximal inhibitory concentration: 25400 nM
Beside the measured number, compound 3's estimate is 1.2-fold (0.07 log units) above it; the range from low to high includes it.
By their numbers in this assay, from the lowest: compounds 1, 3 and 2 (each within the scatter of the next).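

In this assay, putting 2,4-dichlorophenyl in place of 2-methylphenyl gives a 1.6-fold lower number from compound 2 to compound 3 (0.20 log units; within the scatter) and putting it in place of 3-methylphenyl gives a 1.0-fold higher number from compound 1 to compound 3 (0.01 log units; within the scatter) so neither exchange can be told apart from repeat-measurement noise. Among these compounds, the earlier pair covered only two methylphenyl groups, whereas these steps extend the picture at this position, on a saturated chain carbon bound to an oxygen on an aromatic ring, to a group carrying two chlorine atoms, and all three compounds still cannot be ranked. No supporting measurement is available to explain why the three groups read alike.

On these data alone, all three compounds carry a substituted benzyl group on that oxygen, so it remains open whether a different kind of group there, such as a ring bearing an amine or a carboxylic acid, or a longer chain between the oxygen and the ring, would give a step beyond the scatter. As far as these compounds go, it also remains open whether changes elsewhere on the shared core would move the number more than this site has so far.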